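A few compounds are considered here, and "the series" means these few. Any claim that something is new, unique, unknown or untested is made for them only; others in the source may bear on it.

Of the compounds shown here, three have been measured in an ADME assay on the whole organism (Rattus norvegicus, strain Sprague-Dawley) for pharmacokinetics, read by LC-MS, with a stated time of 30 min, at a dose of 1 mg/kg by the intravenous route; a lower number here means slower removal, a higher number faster removal of the compound. Compound 1 `N#Cc1ccc(O[C@H]2CN(S(=O)(=O)c3ccc(Cl)cc3Cl)C[C@@]2(O)CN)cc1F` gives 1100 mL/min/kg and compound 2 `N#Cc1ccc(O[C@H]2CN(S(=O)(=O)c3ccc(Cl)cc3Cl)C[C@]2(O)CO)cc1F` gives 1350 mL/min/kg. Compound 3 `N#Cc1ccc(O[C@H]2CN(S(=O)(=O)c3ccccc3C#N)C[C@@]2(O)CO)cc1F` gives 200 mL/min/kg, the lowest of the three numbers, and the other two lie above it by more than the usual scatter.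

Compound 4 `N#Cc1ccc(O[C@H]2CN(S(=O)(=O)c3ccc(Cl)cc3)C[C@@]2(O)CO)cc1F` has the same core as compound 3 and changes one group: 4-chlorophenyl in place of 2-cyanophenyl on a sulfonyl sulfur. In words, this is 4-chlorophenyl in place of 2-cyanophenyl on a sulfonyl sulfur. For the measured compounds named here, no measured pair shows this change on its own, and any expectation is only a rough one. Going by the values given here, the one clue is that compound 1 at 1100 mL/min/kg and compound 2 at 1350 mL/min/kg also carry chlorine on the aromatic ring on the sulfonyl sulfur, although they differ from compound 3 elsewhere too. In this assay the expected change is a rise beyond the scatter, estimated as a 3.0-fold higher number from compound 3 to compound 4 (0.48 log units; beyond the scatter). Compound 4 is expected at 600 mL/min/kg, with an estimated range from 250 mL/min/kg to 1300 mL/min/kg.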

Compound 4, clearance: 1540 mL/min/kg
For compound 4 the middle estimate is 2.6-fold (0.41 log units) below the measured one; measured number above the stated range.
By their numbers in this assay, from the lowest: compound 3; then compounds 1, 2 and 4 (each within the scatter of the next).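

For the compounds shown here, this step is the first one in which only the aromatic group on the sulfonyl sulfur changes, so the shift can be tied to this one place. In this assay, 4-chlorophenyl in place of 2-cyanophenyl gives a 7.7-fold higher number from compound 3 to compound 4 (0.89 log units; beyond the scatter), which shows that this position alone can move the clearance well beyond the usual scatter while the rest of the molecule stays the same. No measurement available here explains why the clearance changes with this group.

The change removes the nitrile and adds a chlorine, and it also moves the substituent to a different ring position, so the step cannot show which of these matters. It also leaves open where a plain phenyl ring or a methoxyphenyl group on the same sulfonyl sulfur would fall in this assay.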